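A few compounds are considered here, and "the series" means these few. Any claim that something is new, unique, unknown or untested is made for them only; others in the source may bear on it.

Measured compounds:
- compound 1, `Cc1ccc(C)n1-c1cccc(-c2nnn[nH]2)c1`: 250000 nM
- compound 2, `COc1cccc(N2C(=O)/C(=C/c3cc(C)n(-c4cccc(-c5nnn[nH]5)c4)c3C)SC2=S)c1`: 40600 nM
- compound 3, `Cc1cc(/C=C2\SC(=S)N(c3cccc(C(F)(F)F)c3)C2=O)c(C)n1-c1cccc(-c2nnn[nH]2)c1`: 15800 nM

These three compounds were tested in an ADME assay on MT2 cells (Homo sapiens) for cytotoxicity, read by XTT assay, with a stated time of 4 days; on this read-out higher numbers stand for lower toxicity in this test and lower numbers for higher toxicity in this test. Compound 3 gives the lowest number of the three, meaning it is the most toxic in this test: compound 2 sits at 40600 nM, and compound 1, the smallest compound, at 250000 nM. Among the measured compounds shown here, the one step between neighbours, a 2.6-fold lower number from compound 2 to compound 3 (0.41 log units; beyond the scatter), shows that a change on the aromatic ring attached to the amide-type nitrogen in a ring shifts the number modestly.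

Compound 4, `Cc1cc(/C=C2\SC(=S)N(c3ccc(O)cc3)C2=O)c(C)n1-c1cccc(-c2nnn[nH]2)c1`, is not yet measured. It differs from compound 3 by 4-hydroxyphenyl in place of 3-(trifluoromethyl)phenyl on an amide-type nitrogen in a ring. For the measured compounds named here, no measured step covers a hydroxyphenyl group here; the only related step, the one from compound 2 to compound 3, is modest and concerns the same position. The expected step in this assay, a 2.5-fold higher number from compound 3 to compound 4 (0.40 log units; beyond the scatter), is therefore a modest rise, back toward the number of compound 2. The estimate for compound 4 is 40000 nM, with a range from 15000 nM to 120000 nM.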

Compound 4, half-maximal cytotoxic concentration: 45600 nM
Beside the measured number, compound 4's estimate is 1.1-fold (0.06 log units) below it; low and high end bracket the measured number.
By their numbers in this assay, from the lowest: compound 3; then compounds 2 and 4 (each within the scatter of the next); then compound 1.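

In this assay the aromatic group on the amide-type nitrogen in a ring now has a third member, and the step of a 2.9-fold higher number from compound 3 to compound 4 (0.46 log units; beyond the scatter) shows that 4-hydroxyphenyl in place of 3-(trifluoromethyl)phenyl modestly raises the number, which here means lower toxicity in this test. Compared with 3-methoxyphenyl, 4-hydroxyphenyl makes no readable difference, with a step of a 1.1-fold higher number from compound 2 to compound 4 (0.05 log units; within the scatter) and so, among these three groups, only 3-(trifluoromethyl)phenyl stands apart. No measurement shown here explains why these groups give these numbers.

From the compounds shown here alone, it remains open whether a plain phenyl, or a phenyl carrying an amine or a carboxylic acid, would land with compound 2 and compound 4 or with compound 3. A 3-hydroxyphenyl group would show whether moving the hydroxyl on the same ring changes the number.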